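The compounds below may be only part of what the source reports. "The series", "measured", "known", "first", "only" and "open" are said of these compounds alone.

In a functional assay on T47D cells (Homo sapiens) for inhibition, read by CCK-8 assay, with a stated time of 72 h, tested at 10 uM (a higher number here means more inhibition of growth at the concentration tested, a lower number less inhibition of growth), compound 1 `CN(C)C(=O)c1cc2cnc(Nc3ccc(NC(=O)C4(C(=O)Nc5ccc(F)cc5)CC4)cc3)nc2n1C1CCCC1` gives 105%. Compound 2 `CN(C)C(=O)c1cc2cnc(Nc3ccc(NC(=O)C4(C(=O)Nc5ccccc5F)CC4)cc3)nc2n1C1CCCC1`, with 2-fluorophenyl in place of 4-fluorophenyl on an amide-type nitrogen, gives 97.8%. Within the data shown here, these are the only two numbers so far, and they lie within the scatter of each other, so neither compound ranks ahead of the other.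

Compound 3 `CN(C)C(=O)c1cc2cnc(Nc3ccc(NC(=O)C4(C(=O)Nc5ccc(F)cc5)CC4)cc3F)nc2n1C1CCCC1` differs from compound 1 by a single change: fluoro in place of hydrogen on an aromatic carbon. That carbon belongs to a six-membered aromatic ring of carbon only, ortho to a large group and meta to a large group.

Among the measured compounds shown here, no measured step makes this exact change. The nearest evidence is a number 7.2 percentage points lower from compound 1 to compound 2 (within the scatter), which also concerns a fluoro group but in a different part of the molecule, so it offers only a loose guide. It does suggest that a small fluoro change need not shift the read-out much.

In this assay, the expected step is therefore a number 7 percentage points lower from compound 1 to compound 3 (within the scatter), an estimate that stays within the scatter. For compound 3 the estimated value is 98%, with an expected range from 78% to 109%.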

Compound 3, percent growth inhibition at one concentration: 67.9%
Beside the measured number, compound 3's estimate is 30.1 percentage points above it; measured number outside the range, below it.
By their numbers in this assay, from the lowest: compound 3; then compounds 2 and 1 (each within the scatter of the next).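

In this assay, fluoro in place of hydrogen on this aromatic carbon, ortho to a large group and meta to a large group, brings a number 37.1 percentage points lower from compound 1 to compound 3 (beyond the scatter). Among these compounds, this is the first sign that the read-out can respond strongly to a single added fluorine atom, and it shows that a small change is not harmless everywhere on these molecules. The earlier fluoro change sat on a different ring and gave only a number 7.2 percentage points lower from compound 1 to compound 2 (within the scatter), so the position of a fluoro group matters at least as much as its presence in this small set. Nothing available explains the sharp fall in growth inhibition at this carbon.

As far as these compounds go, it remains open whether the fall belongs to fluoro alone or would also come with a chloro or a methyl group on the same carbon. Also open, from the compounds shown here alone, is whether fluoro on the other carbons of this ring would lower the number as far, and whether the fall would persist with 2-fluorophenyl in place of 4-fluorophenyl.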